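This account rests on a few compounds, and the source may have more. Where it says the series, first, only, none or still open, it means among the compounds named here.

Compound 1 `C=C1C[C@]23C[C@@]1(O)CC[C@H]2c1ccc(OS(=O)(=O)c2ccc(C)cc2)c(C)c1[C@@H]3Cn1cc(-c2ccc(Br)cc2)nn1`. In a functional assay on HL-60 cells (Homo sapiens) for cytotoxicity, read by MTT assay, with a stated time of 4 days (a higher number here means a weaker inhibitor, a lower number a stronger inhibitor), compound 1 gives > 20000 nM, which is a limit of the assay and not a number.
Compound 2 `C=C1C[C@]23C[C@@]1(O)CC[C@@H]2c1cccc(C)c1[C@@H]3Cn1cc(-c2ccccc2)nn1`. In this assay compound 2 gives > 20000 nM, again a limit rather than a number.

Compound 2 therefore stands nowhere definite on the numbers shown: it has only a limit, and the other value given is a limit as well. For the measured compounds named here, both measured compounds sit at the limit of > 20000 nM in this assay, at which 2 of the 2 values shown sit, so no step between measured compounds can be drawn, and nothing is known about how the shared core responds to any change on the phenyl of the triazole.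

Compound 3 `C=C1C[C@]23C[C@@]1(O)CC[C@@H]2c1cccc(C)c1[C@@H]3Cn1cc(-c2ccc(C(F)(F)F)cc2)nn1` differs from compound 2 by trifluoromethyl in place of hydrogen on an aromatic carbon.

Going by the values given here, with no measured step to lean on, the expectation for compound 3 rests only on the two limits already seen. Compound 3 is expected to show no step beyond the scatter, a number no higher from compound 2 to compound 3 (the limit leaves the size open), in this assay. Compound 3 is estimated at 20000 nM in this assay, within 5000 nM to 60000 nM, most likely reported once more as a limit.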

Compound 3, half-maximal inhibitory concentration: > 20000 nM
Compound 3 gave a limit, no number (the forecaster's own chance of this, stated with the estimate: 80%); the middle value sits exactly at the limit.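

Compound 3, like compound 2, gives only a limit of the assay and not a number, so no step can be read between them: the limit of > 20000 nM in this assay, at which 3 of the 3 values shown sit.

The compounds shown leave open how trifluoromethyl compares with hydrogen at this place, and whether any change to the shared core would give a readable number in this assay.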